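The source may hold more compounds than are shown below. What is called first, only, known or untested is meant among the compounds shown, and "the series" means these compounds.

Measured so far:
compound 1 `COc1cc(-c2cc(/C=C/C(=O)c3ccc(N)cc3)[nH]n2)cc(OC)c1OC`: 8930 nM
compound 2 `COc1ccc(C(=O)/C=C/c2cc(-c3cc(OC)c(OC)c(OC)c3)n[nH]2)cc1OC`: 6250 nM

Both numbers come from a functional assay on SK-MEL-28 cells (Homo sapiens) for inhibition, read by sulforhodamine B assay, with a stated time of 48 h; a higher number here means that more compound is tolerated, a lower number that less compound is tolerated. Compound 2 gives the lowest of the two numbers, and its nearest neighbour is compound 1, the gap between them lying within the scatter. Within the data shown here, the one step measured, a 1.4-fold lower number from compound 1 to compound 2 (0.15 log units; within the scatter), puts 3,4-dimethoxyphenyl in place of 4-aminophenyl on the carbonyl carbon and stays within the scatter.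

Compound 3 `COc1ccc(C(=O)/C=C/c2cc(-c3cc(OC)c(OC)c(OC)c3)n[nH]2)cc1` is not yet measured. It differs from compound 2 by hydrogen in place of methoxy on an aromatic carbon; read one bond further out, the change is 3,4-dimethoxyphenyl to 4-methoxyphenyl, on the same six-membered aromatic ring that the measured step altered. Among the measured compounds shown here, that step, a 1.4-fold lower number from compound 1 to compound 2 (0.15 log units; within the scatter), is the only one bearing on this change, and it was within the scatter, although it exchanged more of the ring than the present change does. For compound 3, no step beyond the scatter is therefore expected in this assay, a 1.1-fold higher number from compound 2 to compound 3 (0.05 log units; within the scatter). Compound 3 is estimated at 7000 nM, with a range of 2500 nM to 20000 nM.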

Compound 3, concentration lethal to 50% of the cells: 9230 nM
Compound 3: the middle estimate sits 1.3-fold (0.12 log units) below what was measured, and the stated range covers the measured number.
By their numbers in this assay, from the lowest: compounds 2, 1 and 3 (each within the scatter of the next).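

In this assay, hydrogen in place of methoxy on this aromatic carbon, ortho to a methoxy group, gives a 1.5-fold higher number from compound 2 to compound 3 (0.17 log units; within the scatter) and so shows no step beyond the scatter on losing this methoxy. Methoxy in place of amino on an aromatic carbon gives a 1.0-fold higher number from compound 1 to compound 3 (0.01 log units; within the scatter) and thus isolates that exchange on the ring, where the earlier step also added a methoxy, again with no step beyond the scatter. Nothing available accounts for these results.

From the compounds shown here alone, whether hydrogen in place of the remaining methoxy, or a hydroxyl, a fluorine or a carboxylic acid on this ring, would give a step beyond the scatter stays open. Changes elsewhere on the shared core also remain open, as the compounds shown differ only on this ring.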